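Dichlorophenyl variant of compound 1 in the antiproliferative series

This account rests on a few compounds, and the source may have more. Where it says the series, first, only, none or still open, it means among the compounds named here.

The series shares one core: compound 1 `COc1cc(C(=O)c2sc(-c3ccc(Br)cc3)cc2N)cc(OC)c1OC`, compound 2 `COc1cc(C(=O)c2sc(-c3ccncc3)cc2N)cc(OC)c1OC` and compound 3 `COc1cc(C(=O)c2sc(-c3ccccc3Cl)cc2N)cc(OC)c1OC` differ only in the aryl group on the five-membered aromatic ring. In a functional assay on MOLT-4 cells (Homo sapiens) for antiproliferative activity (on this read-out lower numbers stand for stronger inhibition and higher numbers for weaker inhibition), compound 1 gives 92 nM, compound 2 gives 88 nM and compound 3 gives 17 nM. Compound 1 therefore shows the highest number of the three, with compound 2 close by and compound 3 furthest away.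

The steps between them are a 1.0-fold lower number from compound 1 to compound 2 (0.02 log units; within the scatter) and a 5.4-fold lower number from compound 1 to compound 3 (0.73 log units; beyond the scatter); the third pair gives a 5.2-fold lower number from compound 2 to compound 3 (0.71 log units; beyond the scatter).

Compound 4 `COc1cc(C(=O)c2sc(-c3ccc(Cl)c(Cl)c3)cc2N)cc(OC)c1OC` is not yet measured. It differs from compound 1 as follows: 3,4-dichlorophenyl in place of 4-bromophenyl on an aromatic carbon. The step from compound 1 to compound 2 shows that an exchange of the 4-bromophenyl for another aryl group can leave the number unchanged within the scatter, while the step from compound 1 to compound 3 shows that a chlorine on the ring can lower it modestly. Among the compounds with values here, no measured step carries a 3,4-dichlorophenyl, so the expectation is a step of small size, in the direction of a lower number, a 1.4-fold lower number from compound 1 to compound 4 (0.15 log units; within the scatter). For compound 4 in this assay the estimate is 65 nM, within a range of 25 nM to 170 nM.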

Compound 4, half-maximal inhibitory concentration: 270 nM
The estimate for compound 4 lay 4.2-fold (0.62 log units) below the measured number, outside the stated range (above it).
By their numbers in this assay, from the lowest: compound 3; then compounds 2 and 1 (each within the scatter of the next); then compound 4.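

In this assay, the aryl group on the carbon next to the ring sulfur now shows a change that raises the number beyond the scatter (a 2.9-fold higher number from compound 1 to compound 4 (0.47 log units; beyond the scatter); a 3.1-fold higher number from compound 2 to compound 4 (0.49 log units; beyond the scatter)), whereas the earlier exchanges at this position either left it within the scatter or lowered it. Chlorine on the aryl ring therefore does not lower the number in every case: the two chlorine-bearing compounds give the largest step in the series (a 16-fold higher number from compound 3 to compound 4 (1.20 log units; beyond the scatter)), so the effect of this exchange depends on which chlorinated aryl group is present, not merely on chlorine being there. Nothing at hand gives a reason for the rise or for the gap between the two chlorinated compounds.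

The 2-chlorophenyl and 3,4-dichlorophenyl groups differ both in the number of chlorines and in where they stand, so the compounds shown cannot separate these two changes, and a phenyl group with a single chlorine in another place would be needed to do so. Also open, going by these compounds, is how this position responds to groups other than halogens and the pyridin-4-yl, such as a methoxyphenyl or an aminophenyl.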